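Three weak inhibitors and a fourth awaiting measurement

The source may report more compounds than this note shows. Statements on the series, on what has been measured and on what is new or still open speak of the compounds shown alone.

Compound 1 `Cc1ccc(S(=O)(=O)Nc2ccc3c(c2)C(=O)N(Cc2ccc(Cl)cc2)C3=O)cc1` gives 188000 nM. Compound 2 `Cc1ccc(S(=O)(=O)Nc2ccc3c(c2)C(=O)N(CCCCBr)C3=O)cc1` gives > 200000 nM, which is a limit of the assay. Compound 3 `Cc1ccc(S(=O)(=O)Nc2ccc3c(c2)C(=O)N(C)C3=O)cc1` gives > 200000 nM, likewise a limit of the assay.

Within the data shown here, in an assay on isolated protein for inhibition of lysosomal alpha-glucosidase (Rattus norvegicus), read by colorimetric assay (on this read-out lower numbers stand for stronger inhibition and higher numbers for weaker inhibition), compound 1 is the only compound with a number; the other two sit at a limit (the limit of > 200000 nM in this assay, at which 2 of the 3 values shown sit). Compound 1 therefore stands alone, with nothing measured beside it that reads higher or lower within the range of numbers. The two steps away from it, an at least 1.0-fold higher number from compound 1 to compound 2 (0.02 log units; that floor lies within the scatter) and an at least 1.0-fold higher number from compound 1 to compound 3 (0.02 log units; that floor lies within the scatter), each replace the 4-chlorophenyl and each end at the limit, so their size beyond the floor is not readable. The step that the two limits leave unreadable from compound 2 to compound 3 gives no information on size either.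

Compound 4 `Cc1ccc(S(=O)(=O)Nc2ccc3c(c2)C(=O)N(CCOc2ccc(O)cc2)C3=O)cc1` differs from compound 1 by (4-hydroxyphenoxy)methyl in place of 4-chlorophenyl on a saturated chain carbon bound to an amide-type nitrogen in a ring. Both measured steps bear on it, since each also removed the 4-chlorophenyl, and each reached the limit. Compound 4 is therefore expected to be no stronger than compound 1, with the step estimated at a 1.3-fold higher number from compound 1 to compound 4 (0.12 log units; within the scatter). The value of compound 4 is estimated at 250000 nM, between 120000 nM and 600000 nM, with a real chance that only a limit is reported.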

Compound 4, half-maximal inhibitory concentration: 47700 nM
Compound 4: middle estimate off by 5.2-fold (0.72 log units), on the high side; measured number outside the range, below it.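

In this assay, replacing the 4-chlorophenyl on a saturated chain carbon bound to an amide-type nitrogen in a ring no longer always ends at the limit: (4-hydroxyphenoxy)methyl gives a 3.9-fold lower number from compound 1 to compound 4 (0.60 log units; beyond the scatter). Among these compounds, this makes compound 4 the first compound here with a change at this place that reads as stronger inhibition, and it also stands apart from the two compounds at the limit, with an at least 4.1-fold lower number from compound 3 to compound 4 (0.62 log units; beyond the scatter) and an at least 4.1-fold lower number from compound 2 to compound 4 (0.62 log units; beyond the scatter). Those last two steps are floors, so their full size cannot be read: the limit of > 200000 nM in this assay, at which 2 of the 4 values shown sit.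

The compounds shown do not separate the part played by the hydroxyl from that of the ether oxygen or the aromatic ring of the entering group. On these data alone, whether an amine or a carboxylic acid in place of that hydroxyl would give a lower number also remains open.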